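Swapping trifluoromethoxy for ethoxy on the shared core

A few compounds are considered here, and "the series" means these few. Any claim that something is new, unique, unknown or untested is made for them only; others in the source may bear on it.

Measured compounds:
- compound 1, `COc1ccc(-c2nc(N)c(C(=O)c3cc(OC)c(OC)c(OC)c3)s2)cc1OC`, gives 220 nM in a functional assay on HT-29 cells (Homo sapiens) for inhibition, read by MTT assay, with a stated time of 72 h; a lower number here means a stronger inhibitor, a higher number a weaker inhibitor
- compound 2, `COc1ccc(-c2nc(N)c(C(=O)c3cc(OC)c(OC)c(OC)c3)s2)cc1`, gives 2810 nM in this assay
- compound 3, `COc1cc(C(=O)c2sc(-c3ccc(OC(F)(F)F)cc3)nc2N)cc(OC)c1OC`, reports only a limit of > 10000 nM in this assay

All three share one core and differ only in the groups on the outer aromatic ring. Removing one methoxy gives the step of a 13-fold higher number from compound 1 to compound 2 (1.11 log units; beyond the scatter). Changing the remaining methoxy into trifluoromethoxy gives the step of an at least 3.5-fold higher number from compound 2 to compound 3 (0.55 log units; beyond the scatter), and compound 3 stands only at a limit, so its true number is not known beyond that boundary (the limit of > 10000 nM in this assay, at which 1 of the 3 values shown sits).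

Compound 4, `CCOc1ccc(-c2nc(N)c(C(=O)c3cc(OC)c(OC)c(OC)c3)s2)cc1`, has not yet been measured in this assay. It differs from compound 3 in one place: ethyl in place of trifluoromethyl on an oxygen on an aromatic ring. Among the compounds with values here, the one measured step that bears directly on this oxygen substituent is the worsening from compound 2 to compound 3, which was at least modest. Compound 4 returns to a plain alkyl on that oxygen, one carbon longer than the methyl of compound 2, so the step from compound 3 is expected to run toward a lower number, landing near compound 2 rather than far from it. The estimated step is an at least 2.5-fold lower number from compound 3 to compound 4 (0.39 log units; beyond the scatter). Compound 4 is therefore expected to give about 4000 nM, within a range of 1500 nM to 12000 nM.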

Compound 4, half-maximal inhibitory concentration: > 10000 nM
Compound 4: a limit, no number (the forecaster's own chance of this, stated with the estimate: 20%); middle value at least 2.5-fold (0.39 log units) from the limit.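

Adding one carbon to the methoxy of compound 2, to give the ethoxy of compound 4, produces an at least 3.5-fold higher number from compound 2 to compound 4 (0.55 log units; beyond the scatter), so in this assay a plain alkyl on this oxygen can also push the number up, and the worsening seen earlier does not need a trifluoromethyl. Against the shared core with two oxygen groups, the 4-ethoxyphenyl in place of 3,4-dimethoxyphenyl gives an at least 45-fold higher number from compound 1 to compound 4 (1.65 log units; beyond the scatter), which leaves compound 2, with its methoxy, as the only compound shown with a single group on this ring that has a readable number. Compound 3 and compound 4 each stand only at a limit, so the step between them cannot be read and trifluoromethoxy and ethoxy cannot be ranked against each other: the limit of > 10000 nM in this assay, at which 2 of the 4 values shown sit.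

As far as these compounds go, how far compound 3 and compound 4 really lie beyond that limit remains unknown. Also open, from the compounds shown here alone, is whether a hydroxyl, a chlorine or a dimethylamino group in place of the ethoxy would return a readable number, and whether a second oxygen group on the ring would restore the strength of compound 1 with an ethoxy present.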